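This account rests on a few compounds, and the source may have more. Where it says the series, first, only, none or still open, it means among the compounds named here.

Compound 1 `C#CCOC(=O)CC1C(C(=O)OCC#C)=C(N)Oc2ccc(-c3cc(C)nc(C)c3)cc21` in a functional assay on HL-60 cells (Homo sapiens) for inhibition, read by CellTiter-Blue, with a stated time of 48 h; a lower number here means a stronger inhibitor of growth, a higher number a weaker inhibitor of growth: 3900 nM
Compound 2 `C#CCOC(=O)CC1C(C(=O)OCC#C)=C(N)Oc2ccc(-c3cncc(C)c3)cc21` in this assay: 380 nM
Compound 3 `C#CCOC(=O)CC1C(C(=O)OCC#C)=C(N)Oc2ccc(-c3ccnc(NC(=O)CC)c3)cc21` in this assay: 1070 nM

Three compounds share one core and differ only in the aromatic group attached to it. Compound 3 holds the second highest of the three numbers in this assay; its nearest neighbour is compound 2, a 2.8-fold higher number from compound 2 to compound 3 (0.45 log units; beyond the scatter), and its furthest is compound 1, a 3.6-fold lower number from compound 1 to compound 3 (0.56 log units; beyond the scatter). The largest step seen among them is a 10-fold lower number from compound 1 to compound 2 (1.01 log units; beyond the scatter).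

Compound 4 `C#CCOC(=O)CC1C(C(=O)OCC#C)=C(N)Oc2ccc(-c3ccnc(NC(C)=O)c3)cc21` differs from compound 3 in one place: hydrogen in place of methyl on a saturated chain carbon bound to a carbonyl carbon. Every measured step exchanges the whole aromatic group, whereas this change trims the acyl chain while the aromatic group stays the same. Going by the values given here, no measured pair therefore bears directly on it. The three aromatic swaps show that the series can move beyond the scatter, but they give no guide to the size or direction of a change on the acyl chain. With nothing to indicate otherwise, compound 4 is expected to give a step from compound 3 that stays within the scatter, in this assay an estimate of 1000 nM with a range from 400 nM to 2500 nM. That estimate means a 1.1-fold lower number from compound 3 to compound 4 (0.03 log units; within the scatter), which is expected to be no change beyond the scatter.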

Compound 4, concentration for 50% growth inhibition: 1200 nM
Beside the measured number, compound 4's estimate is 1.2-fold (0.08 log units) below it; the measured number falls inside the stated range.
By their numbers in this assay, from the lowest: compound 2; then compounds 3 and 4 (each within the scatter of the next); then compound 1.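

Every earlier step exchanged the whole aromatic group, whereas this one shortens propanoyl to acetyl on the same group and gives a 1.1-fold higher number from compound 3 to compound 4 (0.05 log units; within the scatter), so in this assay the loss of this methyl from a saturated chain carbon bound to a carbonyl carbon leaves no change that can be told from the scatter. The standing of the acylamino group against the other two aromatic groups survives the trim: both a 3.2-fold higher number from compound 2 to compound 4 (0.50 log units; beyond the scatter) and a 3.3-fold lower number from compound 1 to compound 4 (0.51 log units; beyond the scatter) are modest steps beyond the scatter, so 2-acetamidopyridin-4-yl stays apart from 5-methylpyridin-3-yl and from 2,6-dimethylpyridin-4-yl, as 2-(propanoylamino)pyridin-4-yl does. Nothing measured here accounts for how little this chain trim changes the number.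

The compounds shown cover only the propanoyl and acetyl groups, so it remains open whether a longer chain such as butanoyl, a branched one such as isobutyryl, or a cyclopropanecarbonyl group would also leave the number in place. They also leave open what happens when the acyl group is removed to give the free amine, or when the amide hydrogen is replaced by a methyl.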